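Cyclohexyl to cyclopentyl on the amide carbonyl

A few compounds are considered here, and "the series" means these few. Any claim that something is new, unique, unknown or untested is made for them only; others in the source may bear on it.

Compound 1 `CCCC(=O)N1CCC(NS(=O)(=O)c2ccc(NC(=O)C3CCCCC3)c3ccccc23)CC1` and compound 2 `CCCCc1ccc(C(=O)Nc2ccc(S(=O)(=O)NC3CCN(C(=O)CCC)CC3)c3ccccc23)cc1` share one core and differ only at the amide carbonyl. In an in vitro functional assay on CHO/Galpha16 cells for antagonist activity at C-C chemokine receptor type 8 (Homo sapiens), read by FLIPR (on this read-out lower numbers stand for stronger inhibition and higher numbers for weaker inhibition), compound 1 gives 6.1 nM, and compound 2 gives 15.3 nM. That step, a 2.5-fold higher number from compound 1 to compound 2 (0.40 log units; beyond the scatter), is the only one recorded so far, so compound 2 holds the highest number of the two.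

Compound 3 `CCCC(=O)N1CCC(NS(=O)(=O)c2ccc(NC(=O)C3CCCC3)c3ccccc23)CC1` is not yet measured. Its change from compound 2 is cyclopentyl in place of 4-butylphenyl on a carbonyl carbon. Going by the values given here, the one relevant step is the reverse of this kind of change, namely a 2.5-fold higher number from compound 1 to compound 2 (0.40 log units; beyond the scatter), where a carbocycle was exchanged for the 4-butylphenyl group; compound 3 returns to a carbocycle, one ring member smaller than in compound 1. The expectation is therefore a lower number, of about the size seen between compound 1 and compound 2, expressed as a 1.9-fold lower number from compound 2 to compound 3 (0.28 log units; within the scatter). For compound 3 the estimate in this assay is 8 nM, with a range of 3 nM to 20 nM.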

Compound 3, half-maximal inhibitory concentration: 365 nM
Estimate against measurement, compound 3: 46-fold (1.66 log units) below; measured number above the stated range.
By their numbers in this assay, from the lowest: compound 1; then compound 2; then compound 3.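

In this assay cyclopentyl in place of cyclohexyl gives a 60-fold higher number from compound 1 to compound 3 (1.78 log units; beyond the scatter) at this carbonyl carbon, a large step where the earlier exchange of cyclohexyl for 4-butylphenyl was only modest. Cyclopentyl in place of 4-butylphenyl gives a 24-fold higher number from compound 2 to compound 3 (1.38 log units; beyond the scatter) as well, so a non-aromatic carbon ring on this carbonyl does not by itself keep the low numbers, and the position separates cyclopentyl sharply from cyclohexyl. Nothing at hand explains why this change costs so much.

Going by these compounds, whether the loss follows ring size alone remains open, and a cycloheptyl group on the same carbonyl carbon would test that. Also open, on these data alone, is how an open chain such as n-pentyl or a ring bearing an amine would read at this position.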